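Amide nitrogen variation on the shared core

A few compounds are considered here, and "the series" means these few. Any claim that something is new, unique, unknown or untested is made for them only; others in the source may bear on it.

The three measured compounds keep one core and differ only in the group on the amide-type nitrogen. In a functional assay on MIA PaCa-2 cells (Homo sapiens) for inhibition, read by MTT assay, with a stated time of 3 days (on this read-out lower numbers stand for stronger inhibition and higher numbers for weaker inhibition), compound 1 `CCN(CC)S(=O)(=O)c1ccc(S(=O)(=O)N2CCC[C@@H](C(=O)NC3CCOCC3)C2)cc1` gives 1350 nM. Compound 2 `CCN(CC)S(=O)(=O)c1ccc(S(=O)(=O)N2CCC[C@@H](C(=O)N[C@H]3CC[C@@H](OC)CC3)C2)cc1` gives 590 nM in this assay, and compound 3 `CCN(CC)S(=O)(=O)c1ccc(S(=O)(=O)N2CCC[C@@H](C(=O)N[C@@H]3CCOC3)C2)cc1` gives 100 nM. The steps read a 2.3-fold lower number from compound 1 to compound 2 (0.36 log units; beyond the scatter), a 14-fold lower number from compound 1 to compound 3 (1.13 log units; beyond the scatter) and a 5.9-fold lower number from compound 2 to compound 3 (0.77 log units; beyond the scatter). Compound 3 therefore stands lowest of the three, with compound 2 nearest and compound 1 furthest.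

Compound 4 `CCN(CC)S(=O)(=O)c1ccc(S(=O)(=O)N2CCC[C@@H](C(=O)N3CCS(=O)(=O)CC3)C2)cc1` carries the next change: 1,1-dioxothiomorpholin-4-yl in place of (oxolan-3-yl)amino on a carbonyl carbon. Among the compounds with values here, no measured step removes the amide hydrogen, so that part of the change has no direct precedent. The bearing steps are those that swap ring size on the amide nitrogen: a 14-fold lower number from compound 1 to compound 3 (1.13 log units; beyond the scatter) and a 5.9-fold lower number from compound 2 to compound 3 (0.77 log units; beyond the scatter) both show a six-membered substituent giving a clearly higher number than oxolan-3-yl. Compound 4 returns to a six-membered ring and in addition drops the donor, so a step back upward in this assay, of roughly the size seen from compound 1 to compound 3 but reversed, is expected. Compound 4 is accordingly estimated at 1500 nM, with a range from 400 nM to 6000 nM. This expected step is a 15-fold higher number from compound 3 to compound 4 (1.18 log units; beyond the scatter).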

Compound 4, half-maximal inhibitory concentration: 220 nM
The estimate for compound 4 lay 6.8-fold (0.83 log units) above the measured number; measured number outside the range, below it.
By their numbers in this assay, from the lowest: compound 3; then compound 4; then compound 2; then compound 1.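

At this carbonyl carbon the amide hydrogen can be lost without a return to the highest numbers: in this assay the change to 1,1-dioxothiomorpholin-4-yl gives a 2.2-fold higher number from compound 3 to compound 4 (0.34 log units; beyond the scatter) and leaves compound 3 lowest of the four, though that step is beyond the scatter. A six-membered ring here also no longer goes with the high end of the series: the same group gives a 2.7-fold lower number from compound 2 to compound 4 (0.43 log units; beyond the scatter) and a 6.1-fold lower number from compound 1 to compound 4 (0.79 log units; beyond the scatter) in this assay, so compound 4 goes against the order by ring size that compound 1, compound 2 and compound 3 suggested. No measurement here bears on why this group behaves differently from the other six-membered substituents.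

The change to compound 4 alters the ring size, the amide hydrogen and the ring sulfur with its two oxygens all at once, and the compounds shown do not separate these parts. On these data alone, a morpholin-4-yl or thiomorpholin-4-yl group on the same carbonyl carbon, or a methyl on the amide nitrogen of compound 3, would isolate one part at a time, and how much each contributes remains open.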